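Swapping Chloro for Phenyl Next to the Ring Oxygen

The compounds below may be only part of what the source reports. "The series", "measured", "known", "first", "only" and "open" are said of these compounds alone.

Compound 3 `COc1ccc(CNC(=O)/C(C#N)=C/c2ccc(Cl)o2)cc1` gives 15000 nM in a functional assay on NCI-H460 cells (Homo sapiens) for inhibition, read by MTT assay, with a stated time of 72 h (a lower number here means a stronger inhibitor of growth, a higher number a weaker inhibitor of growth), the lowest of the two numbers shown. Compound 1 `COc1ccc(CNC(=O)/C(C#N)=C/c2ccco2)cc1` gives 32000 nM in this assay. Compound 2 `COc1ccc(CNC(=O)/C(C#N)=C/c2ccc(C)o2)cc1` reaches only a limit of this assay, > 100000 nM. The measured steps are a 2.1-fold lower number from compound 1 to compound 3 (0.33 log units; beyond the scatter), an at least 6.6-fold lower number from compound 2 to compound 3 (0.82 log units; beyond the scatter), which rests on (the limit of > 100000 nM in this assay, at which 1 of the 3 values shown sits), and an at least 3.1-fold higher number from compound 1 to compound 2 (0.49 log units; beyond the scatter).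

Compound 4 `COc1ccc(CNC(=O)/C(C#N)=C/c2ccc(-c3ccccc3)o2)cc1` differs from compound 3 by phenyl in place of chloro on an aromatic carbon. Among the measured compounds shown here, no measured step introduces a ring at this carbon; the steps show only that methyl weakened and chloro strengthened growth inhibition relative to hydrogen, so a larger group here is expected to give a modestly higher number. Compound 4 is therefore estimated at 30000 nM, with a range from 8000 nM to 100000 nM. The expected step is a 2.0-fold higher number from compound 3 to compound 4 (0.30 log units; within the scatter).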

Compound 4, concentration for 50% growth inhibition: > 100000 nM
Compound 4: no number, only a limit (the forecaster's own chance of this, stated with the estimate: 20%); middle value at least 3.3-fold (0.52 log units) from the limit.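

In this assay, phenyl next to the ring oxygen does not keep the gain seen with chloro, giving an at least 6.6-fold higher number from compound 3 to compound 4 (0.82 log units; beyond the scatter). Phenyl also falls short of hydrogen, with an at least 3.1-fold higher number from compound 1 to compound 4 (0.49 log units; beyond the scatter), so among the groups shown only chloro, in compound 3, gives a lower number than hydrogen, while methyl and phenyl both go against it. Compound 2 and compound 4 each rest on a limit and not a number, so the step between them cannot be read: the limit of > 100000 nM in this assay, at which 2 of the 4 values shown sit.

Going by these compounds, whether bromo, an amine or a methoxy group at this carbon would behave like chloro remains open. So does whether a smaller ring, such as cyclopropyl, would behave like phenyl.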